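A few compounds are considered here, and "the series" means these few. Any claim that something is new, unique, unknown or untested is made for them only; others in the source may bear on it.

Measured so far in an assay on CHO cells for displacement of a labelled ligand from adenosine receptor A1 (Homo sapiens), read by scintillation counting, with a stated time of 120 min, tested at 10 uM; a lower number here means less inhibition, a higher number more inhibition at the concentration tested (going by the name of the read-out): compound 1 `CC(C)N1CCN(Cc2csc(N)c2C(=O)c2ccc(Cl)cc2)CC1` gives 0%; compound 2 `Nc1scc(CN2CCN(c3ccncc3)CC2)c1C(=O)c1ccc(Cl)cc1` gives 1%; compound 3 `Nc1scc(CN2CCN(c3cccc4ccccc34)CC2)c1C(=O)c1ccc(Cl)cc1` gives 1%.

Compound 3 stands level with compound 2 at the digits shown, and the two together hold the highest of the three numbers; its nearest neighbour shows no change at the digits printed from compound 2 to compound 3 (within the scatter) and its furthest shows a number 1 percentage points higher from compound 1 to compound 3 (within the scatter). Compound 4 `Nc1scc(CN2CCN(c3cccc(F)c3F)CC2)c1C(=O)c1ccc(Cl)cc1` differs from compound 3 by 2,3-difluorophenyl in place of naphthalen-1-yl on an amine nitrogen in a ring. Every measured step swaps the group on the amine nitrogen in a ring, and each was small: a number 1 percentage points higher from compound 1 to compound 2 (within the scatter), a number 1 percentage points higher from compound 1 to compound 3 (within the scatter) and no change at the digits printed from compound 2 to compound 3 (within the scatter). On that record no step beyond the scatter is expected for compound 4 in this assay, so the expected step is no change at the digits printed from compound 3 to compound 4 (within the scatter). Compound 4 is therefore estimated at 1%, within a range from -5% to 10%.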

Compound 4, a percentage reported as inhibition, at one concentration (the size of the read-out at that concentration, not a potency): 0%
For compound 4 the middle estimate is 1 percentage points above the measured one; measured number inside the range.
By their numbers in this assay, from the lowest: compounds 1, 4, 2 and 3 (each within the scatter of the next).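

In this assay a fluorinated aromatic group now joins the record: 2,3-difluorophenyl on the amine nitrogen in a ring gives a number 1 percentage points lower from compound 3 to compound 4 (within the scatter) against naphthalen-1-yl, a number 1 percentage points lower from compound 2 to compound 4 (within the scatter) against pyridin-4-yl and no change at the digits printed from compound 1 to compound 4 (within the scatter) against isopropyl. Fluorine on a single carbon-only aromatic ring thus adds no step beyond the scatter at this position, and the same holds for the swap from two aromatic rings to one. Nothing available explains this result.

On these data alone, whether a benzyl group or a longer chain ending in a carboxylic acid on this nitrogen would give a step beyond the scatter remains open. So does whether a change elsewhere on the shared core would do so.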